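The source may report more compounds than this note shows. Statements on the series, on what has been measured and on what is new or still open speak of the compounds shown alone.

Measured compounds:
- compound 1 `COc1cc(-c2cc(/C=C/C(=O)c3ccc(Cl)c(Cl)c3)[nH]n2)cc(OC)c1OC`: -36%
- compound 2 `COc1ccc(C(=O)/C=C/c2cc(-c3cc(OC)c(OC)c(OC)c3)n[nH]2)cc1OC`: -96%

Both were tested in a functional assay on OVCAR-8 cells (Homo sapiens) for cytotoxicity, read by sulforhodamine B assay, with a stated time of 48 h, tested at 100 uM; a higher number here means a weaker effect of the compound at the concentration tested, a lower number a stronger effect. Compound 2 stands lowest of the two numbers, the stronger effect at this concentration; its nearest neighbour is compound 1, which differs from it in one place, and the step of a number 60 percentage points lower from compound 1 to compound 2 (beyond the scatter) is large and beyond the scatter.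

Compound 3 `COc1cc(-c2cc(/C=C/C(=O)c3ccc(F)c(F)c3)[nH]n2)cc(OC)c1OC` has not been measured in this assay . It differs from compound 2 by 3,4-difluorophenyl in place of 3,4-dimethoxyphenyl on a carbonyl carbon. Going by the values given here, the one measured step that bears on this change is the one from compound 1 to compound 2, in which a halogenated ring on the carbonyl carbon gave way to the dimethoxy ring and the number fell by a large amount. Compound 3 carries a halogenated ring again, though with fluorine rather than chlorine, so a step back upward in this assay is expected, roughly of the size a number 46 percentage points higher from compound 2 to compound 3 (beyond the scatter). Because compound 1 gives -36% with its dichloro ring, compound 3 is estimated at -50% in this assay , with a range from -95% to -5%.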

Compound 3, a percentage reported as activity, at one concentration (the size of the read-out at that concentration, not a potency): -12%
Compound 3: middle estimate off by 38 percentage points, on the low side; the measured number falls inside the stated range.
By their numbers in this assay, from the lowest: compound 2; then compound 1; then compound 3.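

In this assay, 3,4-difluorophenyl in place of 3,4-dimethoxyphenyl on the carbonyl carbon gives a number 84 percentage points higher from compound 2 to compound 3 (beyond the scatter), so a second halogenated ring also stands well above the dimethoxy ring, and the large gap first seen with the dichloro ring is not specific to chlorine. The choice of halogen matters too: 3,4-difluorophenyl in place of 3,4-dichlorophenyl gives a number 24 percentage points higher from compound 1 to compound 3 (beyond the scatter), a modest step but beyond the scatter, which shows that this position separates the two halogenated rings as well as separating them from the dimethoxy ring. No measurement here explains why these ring changes move the number in this way.

The compounds shown leave open whether the low number of compound 2 depends on having both methoxy groups, or whether a ring with a single methoxy group, an amine or a carboxylic acid would fall near it or near the halogenated compounds. From the compounds shown here alone, each compound also has a reading at just one concentration, so how the three compare in potency remains unknown.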